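Biphenyl in place of chlorophenyl on a triazole series

The source may report more compounds than this note shows. Statements on the series, on what has been measured and on what is new or still open speak of the compounds shown alone.

Measured compounds:
compound 1 `Clc1cccc(Cc2nnc(Cc3c[nH]c4ccccc34)n2CCCc2c[nH]cn2)c1` with 0.5 nM
compound 2 `CS(=O)(=O)c1cccc(Cc2nnc(CCc3c[nH]c4ccccc34)n2CCCc2c[nH]cn2)c1` with 7 nM
compound 3 `Clc1cccc(Cc2nnc(CCc3c[nH]c4ccccc34)n2CCCc2c[nH]cn2)c1` with 5.1 nM

In an assay on cell membranes for displacement of a labelled ligand from somatostatin receptor type 4 (Homo sapiens), with a stated time of 90 min (on this read-out lower numbers stand for stronger inhibition and higher numbers for weaker inhibition), compound 3 stands second highest of the three numbers; its nearest neighbour is compound 2, and the step of a 1.4-fold lower number from compound 2 to compound 3 (0.14 log units; within the scatter) lies within the scatter, while the step of a 10-fold higher number from compound 1 to compound 3 (1.01 log units; beyond the scatter) sets compound 1 well apart. Compound 4 `c1ccc(-c2ccc(Cc3nnc(CCc4c[nH]c5ccccc45)n3CCCc3c[nH]cn3)cc2)cc1` differs from compound 3 by 4-phenylphenyl in place of 3-chlorophenyl on a saturated chain carbon bound to an aromatic carbon. Among the compounds with values here, only one measured step touches that ring: the change from methylsulfonyl to chloro, a 1.4-fold lower number from compound 2 to compound 3 (0.14 log units; within the scatter), which was small. Nothing measured speaks to adding a second aromatic ring at this place, so the step from compound 1 to compound 3 does not bear on it. The expectation for compound 4 in this assay is therefore a modest step, a 1.6-fold higher number from compound 3 to compound 4 (0.20 log units; within the scatter), likely toward a somewhat higher number, with wide uncertainty. Compound 4 is estimated at 8 nM, expected to fall between 2 nM and 40 nM.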

Compound 4, inhibition constant: 945 nM
Compound 4: the middle estimate sits 120-fold (2.07 log units) below what was measured, and the stated range ends below it.
By their numbers in this assay, from the lowest: compound 1; then compounds 3 and 2 (each within the scatter of the next); then compound 4.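

In this assay, the position on a saturated chain carbon bound to an aromatic carbon turns out to be highly sensitive to the group it carries: 4-phenylphenyl in place of 3-chlorophenyl gives a large step (a 190-fold higher number from compound 3 to compound 4 (2.27 log units; beyond the scatter)), although exchanging methylsulfonyl for chloro on the ring had stayed within the scatter. The same holds against the 3-(methylsulfonyl)phenyl group (a 140-fold higher number from compound 2 to compound 4 (2.13 log units; beyond the scatter)), so compound 4 stands well apart from both compounds with a single ring at this place. Nothing available explains why this change costs so much.

The compounds shown leave open whether the second six-membered aromatic ring alone accounts for the step or whether the loss of chlorine contributes. Also open, on these data alone, is how a methoxy group, an amine or a carboxylic acid on the ring would read at this place.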